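From 4-chlorophenyl to 2-chlorophenyl on compound 1

This account rests on a few compounds, and the source may have more. Where it says the series, first, only, none or still open, it means among the compounds named here.

Among the compounds with values here, compound 1 `O=C(CCSc1nnc(-c2ccncc2)s1)Nc1ccc(Cl)cc1` is the reference point in an ADME assay on BHK-21 cells (Mesocricetus auratus) for cytotoxicity, with a stated time of 3 days (on this read-out higher numbers stand for lower toxicity in this test and lower numbers for higher toxicity in this test), where compound 1 gives 8210 nM, the only exact number in this small set. Compound 3 `CC(CSc1nnc(-c2ccncc2)s1)C(=O)Nc1ccc(Cl)cc1` gives > 50000 nM, which is a limit of the assay. For compound 2 `CC(Sc1nnc(-c2ccncc2)s1)C(=O)NCc1ccc(Cl)cc1` the entry reads "not determined" (no result reported).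

Within the data shown here, the only measured step, an at least 6.0-fold higher number from compound 1 to compound 3 (0.78 log units; beyond the scatter), alters the chain and leaves the chlorophenyl group untouched. It shows that one small change can move this read-out, but it does not address the aromatic group.

Among the measured compounds shown here, compound 4 `O=C(CCSc1nnc(-c2ccncc2)s1)Nc1ccccc1Cl` keeps the chain of compound 1 and changes only that group: 2-chlorophenyl in place of 4-chlorophenyl on an amide-type nitrogen. For the measured compounds named here, no measured step covers this kind of change, so no shift beyond the scatter is expected in this assay, and the direction remains open. The expected step is a 1.2-fold higher number from compound 1 to compound 4 (0.09 log units; within the scatter). For compound 4 the estimated value is 10000 nM, with an expected range from 3500 nM to 30000 nM.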

Compound 4, half-maximal cytotoxic concentration: > 50000 nM
Compound 4: a limit, no number; the forecaster's own chance of this, stated with the estimate: 15%; at least 5.0-fold (0.69 log units) between middle value and limit.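

In this assay, the aromatic group on the amide-type nitrogen proves able to move the read-out: 2-chlorophenyl in place of 4-chlorophenyl gives an at least 6.0-fold higher number from compound 1 to compound 4 (0.78 log units; beyond the scatter). Until now only a change in the chain had shown such a shift, whereas here the chain of compound 1 stays as it is and the same atoms, joined differently, are enough. Compound 4 gives a limit and not a number, so the full size of this step cannot be read: the limit of > 50000 nM in this assay, at which 2 of the 4 values shown sit.

From the compounds shown here alone, it stays open how plain phenyl, 2-fluorophenyl or 2-methylphenyl on the amide-type nitrogen would read, and so whether the shift belongs to chlorine in particular. Also open, going by these compounds, is how the methyl on the chain of compound 3 would read together with the 2-chlorophenyl group.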